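The source may report more compounds than this note shows. Statements on the series, on what has been measured and on what is new or still open speak of the compounds shown alone.

Compound 2 `O=C(NCCCOc1ccc2nc(O)ccc2c1)N(C1CC1)[C@H]1CC[C@H](O)CC1` gives, in a functional assay on the whole organism for inhibition, with Mus musculus as the target, at a dose of 30 mg/kg by the oral route (on this read-out higher numbers stand for more inhibition at the one dose given (going by the name of the read-out) and lower numbers for less inhibition), 0%, the lowest of the two numbers shown. Compound 1 `O=C(NCCCOc1ccc2nc(O)ccc2c1)N(C1CCCC1)[C@H]1CCCC[C@@H]1O` gives 78% in this assay. The change from compound 2 to compound 3 `O=C(NCCCOc1ccc2nc(O)ccc2c1)N(C1CC1)[C@H]1CCCC[C@@H]1O` is 2-hydroxycyclohexyl in place of 4-hydroxycyclohexyl on an amide-type nitrogen. Among the compounds with values here, no single-point step between measured compounds exists here, yet compound 1, which also carries the entering group, shows the higher value. The step from compound 2 to compound 3 is therefore expected to be a rise beyond the scatter, a number 50 percentage points higher from compound 2 to compound 3 (beyond the scatter). Compound 3 is estimated at 50% in this assay, between 10% and 85%.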

Compound 3, a percentage reported as inhibition, in the whole organism at one dose (the size of the read-out at that dose, not a potency): 100%
For compound 3 the middle estimate is 50 percentage points below the measured one; measured number above the stated range.
By their numbers in this assay, from the lowest: compound 2; then compound 1; then compound 3.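

In this assay, 2-hydroxycyclohexyl in place of 4-hydroxycyclohexyl on the amide-type nitrogen gives a number 100 percentage points higher from compound 2 to compound 3 (beyond the scatter); the two groups hold the same atoms, so how they are joined alone separates these compounds. With 2-hydroxycyclohexyl held constant, cyclopropyl in place of cyclopentyl gives a number 22 percentage points higher from compound 1 to compound 3 (beyond the scatter), so high inhibition at this dose does not require cyclopentyl. Nothing available explains either step. Still open, going by these compounds, are how 3-hydroxycyclohexyl would compare and whether a 2-aminocyclohexyl or 2-methoxycyclohexyl group would retain the inhibition seen with 2-hydroxycyclohexyl.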